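Removing a Methyl from a Saturated Ring Carbon

The source may hold more compounds than are shown below. What is called first, only, known or untested is meant among the compounds shown, and "the series" means these compounds.

Among the compounds with values here, compound 2 `CC1CCN(c2c(S(=O)(=O)c3ccccc3)cnc3ccccc23)CC1` stands highest of the two numbers measured so far in an assay on isolated protein for displacement of a labelled ligand from metabotropic glutamate receptor 5 (Homo sapiens), with a stated time of 60 min, tested at 1 uM (on this read-out higher numbers stand for more inhibition at the one concentration tested (going by the name of the read-out) and lower numbers for less inhibition), where compound 2 gives 89.2%. Its nearest neighbour is compound 1 `O=S(=O)(c1ccccc1)c1cnc2ccccc2c1N1CCCCCC1`, which in this assay gives 79.9%; the step of a number 9.3 percentage points higher from compound 1 to compound 2 (within the scatter) lies within the scatter, so no order can be read between these two compounds. Compound 3 `O=S(=O)(c1ccccc1)c1cnc2ccccc2c1N1CCCCC1` has not yet been measured. It differs from compound 2 in one place: hydrogen in place of methyl on a saturated ring carbon. Within the data shown here, the only measured step that bears on this change is a number 9.3 percentage points higher from compound 1 to compound 2 (within the scatter), which exchanged azepan-1-yl for 4-methylpiperidin-1-yl on an aromatic carbon and stayed within the scatter. The change to compound 3 again alters only the saturated ring attached at that aromatic carbon, and with a single comparable step that itself lay within the scatter, no movement beyond the scatter is expected in this assay. Compound 3 is therefore estimated to give 85%, within 70% to 95%, a step of a number 4.2 percentage points lower from compound 2 to compound 3 (within the scatter) that is expected to remain within the scatter.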

Compound 3, a percentage reported as inhibition, at one concentration (the size of the read-out at that concentration, not a potency): 71.4%
The estimate for compound 3 lay 13.6 percentage points above the measured number; measured number inside the range.
By their numbers in this assay, from the lowest: compounds 3, 1 and 2 (each within the scatter of the next, the first and the last beyond it).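

In this assay, within the data shown here, replacing the methyl with hydrogen, which turns 4-methylpiperidin-1-yl into piperidin-1-yl, gave a number 17.8 percentage points lower from compound 2 to compound 3 (beyond the scatter) and so produced the first step in this set to lie beyond the scatter. The read-out therefore responds to this saturated ring carbon, three ring bonds from the ring nitrogen, even though the change removes only one heavy atom. Exchanging azepan-1-yl for piperidin-1-y1 gave a number 8.5 percentage points lower from compound 1 to compound 3 (within the scatter) and stayed within the scatter, so compound 1 cannot be ordered against either compound 2 or compound 3, and the methyl step alone separates two compounds here; nothing available explains that step.

The compounds shown leave open whether the response belongs to the methyl in particular or would also appear with an ethyl, a hydroxyl or an amine on the same ring carbon. They also leave open how a methyl would read on another carbon of the piperidine ring, and, since each number comes from one concentration, how far the step reflects a difference in potency.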